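This account rests on a few compounds, and the source may have more. Where it says the series, first, only, none or still open, it means among the compounds named here.

Of the compounds shown here, two have been tested so far in a functional assay on the whole organism with Rattus norvegicus as the target; on this read-out lower numbers stand for an effect already at smaller amounts and higher numbers for an effect only at larger amounts of compound. Compound 1 `O=C(O)c1cc(-c2ccccc2)ccc1O` gives 54 mg/kg, and compound 2 `CC(=O)Oc1ccc(-c2ccc(F)cc2F)cc1C(=O)O` gives 27 mg/kg. These two numbers lie within the usual scatter of each other, so compound 2 stands level with compound 1 on this read-out.

Compound 3 `CCOC(=O)Oc1ccc(-c2ccc(F)cc2F)cc1C(=O)O` has not been measured yet. It differs from compound 2 in one small place: ethoxy in place of methyl on a carbonyl carbon. Seen one bond further out, this turns acetoxy into (ethoxycarbonyl)oxy. The rest of the structure stays the same.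

Going by the values given here, no two measured compounds differ in just one place, so the data show no direct example of how much a single change like this moves the number. With nothing pointing either way, the expectation is no shift beyond the scatter. The estimated change is a 1.0-fold higher number from compound 2 to compound 3 (0.02 log units; within the scatter). For compound 3 the expected value is 28 mg/kg, with an estimated range from 12 mg/kg to 60 mg/kg.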

Compound 3, dose for half-maximal effect: 30 mg/kg
Estimate against measurement, compound 3: 1.1-fold (0.03 log units) below; the measured number falls inside the stated range.
By their numbers in this assay, from the lowest: compounds 2, 3 and 1 (each within the scatter of the next).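

Going by these compounds alone, compound 2 and compound 3 are the first measured compounds that differ in just one place, so this is the first direct view of a single change on this scaffold. In this assay, putting ethoxy in place of methyl on a carbonyl carbon, which turns acetoxy into (ethoxycarbonyl)oxy, gives a 1.1-fold higher number from compound 2 to compound 3 (0.05 log units; within the scatter) and leaves the two compounds level. At this position, then, a group of 3 heavy atoms with 1 hydrogen-bond acceptor stands in for a group of 1 heavy atom with none, and the whole-animal read-out does not separate the two; no measurement shown here goes any way towards explaining this outcome.

As far as these compounds go, this is a single swap, so it remains open whether a longer chain such as butoxy, or an amine on the same carbonyl carbon, would give a number beyond the scatter. Compound 1 differs from compound 2 and compound 3 in more than one place, so the effect of the two fluorines on the outer ring and that of the group on the oxygen cannot yet be told apart.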